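The source may report more compounds than this note shows. Statements on the series, on what has been measured and on what is new or still open speak of the compounds shown alone.

Compound 1 `Cc1ccnc(NC(c2ccc3cccnc3c2O)c2c(F)cccc2Cl)c1` is reported in an assay for inhibition of protein disulfide-isomerase (Homo sapiens), with a stated time of 1 h (a lower number here means a stronger inhibitor, a higher number a weaker inhibitor), only as a limit, at > 40000 nM. Compound 2 `Oc1ccc2[nH]ncc2c1C(c1ccc(-c2cncnc2)cc1)N1CCCCC1` gives the single actual number shown, 830 nM in this assay. Compound 3 `Oc1ccc2[nH]ncc2c1C(c1ccc(-c2nccs2)cc1)N1CCCCC1` differs from compound 2 in one place: 1,3-thiazol-2-yl in place of pyrimidin-5-yl on an aromatic carbon. No step between two measured compounds is shown, so there is nothing to set the size of this change against. The step of a 1.1-fold higher number from compound 2 to compound 3 (0.04 log units; within the scatter) is expected to stay within the usual scatter, with no clear direction. Compound 3 is therefore estimated at 900 nM in this assay, within 300 nM to 3000 nM.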

Compound 3, half-maximal inhibitory concentration: 340 nM
Compound 3: middle estimate off by 2.6-fold (0.42 log units), on the high side; the range from low to high includes it.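

The aromatic carbon para to a large group is sensitive to which ring it carries: in this assay, 1,3-thiazol-2-yl in place of pyrimidin-5-yl gives a 2.4-fold lower number from compound 2 to compound 3 (0.39 log units; beyond the scatter). For the compounds shown here, compound 1 and compound 2 alone could not show this, as they offered no step at any one position. Nothing measured here accounts for the size of this step. On these data alone, whether a plain phenyl ring, an amine or a carboxylic acid at this position would give a lower or higher number remains open.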